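The source may hold more compounds than are shown below. What is called first, only, known or untested is meant among the compounds shown, and "the series" means these compounds.

Measured so far in an ADME assay on L02 cells (Homo sapiens) for cytotoxicity, read by MTT assay, with a stated time of 24 h; a higher number here means a weaker inhibitor, a lower number a stronger inhibitor:
compound 1 `Cc1ccc(S(=O)(=O)N2C/C(=C\c3cccnc3)C(=O)/C(=C/c3ccccc3F)C2)cc1`: 14900 nM
compound 2 `O=C1/C(=C/c2cccnc2)CN(S(=O)(=O)c2ccc([N+](=O)[O-])cc2)C/C1=C\c1ccccc1F`: > 20000 nM (a limit of the assay, not a number)

Compound 2 has no number to place it: it stands at the limit of > 20000 nM in this assay, at which 1 of the 2 values shown sits. Compound 3 `O=C1/C(=C/c2cccnc2)CN(S(=O)(=O)c2ccc(C(F)(F)F)cc2)C/C1=C\c1ccccc1F` keeps the shared core and carries trifluoromethyl in place of nitro on an aromatic carbon, para to a large group, so that 4-nitrophenyl becomes 4-(trifluoromethyl)phenyl: trifluoromethyl in place of nitro on an aromatic carbon.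

Within the data shown here, one measured step bears on this change, since it also replaces the group on that aromatic carbon. It is an at least 1.3-fold higher number from compound 1 to compound 2 (0.12 log units; that floor lies within the scatter), with nitro in place of methyl. That step gives only a floor, so it sets no size for a further change of this group. Among the measured compounds shown here, the only true number is that of compound 1, at 14900 nM. No step beyond the scatter is therefore expected in this assay, and no direction can be firmly expected. The estimated step is an at least 1.1-fold lower number from compound 2 to compound 3 (0.04 log units; that floor lies within the scatter). For compound 3 the expected value is 18000 nM, with an estimated range of 9000 nM to 36000 nM.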

Compound 3, half-maximal inhibitory concentration: 11300 nM
Compound 3: middle estimate off by 1.6-fold (0.20 log units), on the high side; the measured number falls inside the stated range.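

In this assay, the aromatic carbon para to a large group now carries two groups with true numbers rather than one number and a limit. The step between them is a 1.3-fold lower number from compound 1 to compound 3 (0.12 log units; within the scatter), so methyl and trifluoromethyl are not separated at this position, and the exchange of one for the other leaves the read-out inside the usual scatter. The step for the change itself is an at least 1.7-fold lower number from compound 2 to compound 3 (0.24 log units; that floor lies within the scatter), and it can be read only as a floor because compound 2 holds a limit of the assay and not a number: the limit of > 20000 nM in this assay, at which 1 of the 3 values shown sits.

Going by these compounds, the true distance between nitro and trifluoromethyl at this position stays open, and so does any ordering of nitro against methyl, since the only figures available for nitro are floors that lie within the scatter. Also open is whether a group of another kind on the same aromatic carbon, such as an amine or a carboxylic acid, would give a step beyond the scatter in this assay, as the three groups shown do not establish one.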